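A Methyl-to-Bromo Swap with Little Expected Change

The source may report more compounds than this note shows. Statements on the series, on what has been measured and on what is new or still open speak of the compounds shown alone.

Compound 2 `Cc1ccc(S(=O)(=O)c2nc3ccccc3nc2N2CCCC(O)C2)cc1` carries a 4-methylphenyl group on the shared core. Among the compounds with values here, in a functional assay on PC-3 cells (Homo sapiens) for cytotoxicity, read by MTT assay, with a stated time of 72 h (a higher number here means a weaker inhibitor, a lower number a stronger inhibitor), compound 2 gives 5330 nM, the only number in the set. Compound 1 `O=S(=O)(c1ccc(Br)cc1)c1nc2ccccc2nc1N1CCc2ccccc2C1` pairs a bromo-bearing ring with a different amine and reaches only a limit of the assay: in this assay compound 1 gives > 50000 nM. Within the data shown here, compound 1 and compound 2 differ in two places, so no single step connects them; their two values show only that one gave a number and the other a limit (the limit of > 50000 nM in this assay, at which 1 of the 2 values shown sits).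

Compound 3 `O=S(=O)(c1ccc(Br)cc1)c1nc2ccccc2nc1N1CCCC(O)C1` keeps the amine of compound 2 and changes only the aromatic ring: bromo in place of methyl on an aromatic carbon, so that 4-methylphenyl becomes 4-bromophenyl. Among the measured compounds shown here, no measured pair isolates this change. The expected step of a 1.3-fold higher number from compound 2 to compound 3 (0.12 log units; within the scatter) would sit within the usual scatter. Compound 3 is therefore estimated at 7000 nM, with a range from 2500 nM to 25000 nM.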

Compound 3, half-maximal inhibitory concentration: 3690 nM
For compound 3 the middle estimate is 1.9-fold (0.28 log units) above the measured one; low and high end bracket the measured number.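

In this assay, bromo in place of methyl on an aromatic carbon gives a 1.4-fold lower number from compound 2 to compound 3 (0.16 log units; within the scatter), so compound 2 and compound 3 cannot be told apart at this position, para to a large group. With the 4-bromophenyl group held fixed, the amine can now be read on its own: 3-hydroxypiperidin-1-yl in place of 1,2,3,4-tetrahydroisoquinolin-2-yl gives an at least 13-fold lower number from compound 1 to compound 3 (1.13 log units; beyond the scatter), a large step that the earlier pair, differing in two places, could not isolate. The reading for compound 1 is a limit of the assay, not a number, so the true size of that step stays unknown: the limit of > 50000 nM in this assay, at which 1 of the 3 values shown sits.

From the compounds shown here alone, whether the amine step would be as large with 4-methylphenyl in place of 4-bromophenyl remains open. Also open, going by these compounds, is how a methoxy group or a nitrile at the same ring position, or a morpholine in place of the amine, would read on the shared core.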